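From 2,3-dihydroxyphenyl to 2-(difluoromethoxy)phenyl on a shared core

The source may hold more compounds than are shown below. What is called first, only, known or untested is meant among the compounds shown, and "the series" means these compounds.

Compound 1 `OC[C@H]1O[C@@H](n2cnc3c(NCc4ccc(F)cc4)ncnc32)[C@H](O)[C@@H]1O`: 21000 nM
Compound 2 `COc1cccc(CNc2ncnc3c2ncn3[C@@H]2O[C@H](CO)[C@@H](O)[C@H]2O)c1OC`: > 166000 nM (a limit)
Compound 3 `OC[C@H]1O[C@@H](n2cnc3c(NCc4cccc(O)c4O)ncnc32)[C@H](O)[C@@H]1O`: 5200 nM

All three compounds were tested in a functional assay on MCF cells (Homo sapiens) for antiproliferative activity, with a stated time of 72 h (a lower number here means a stronger inhibitor, a higher number a weaker inhibitor), and differ only in the aryl group on the shared core. Compound 3, at 5200 nM, has the lower of the two exact numbers. Its nearest neighbour is compound 1, at 21000 nM, and the change is modest: a 4.0-fold lower number from compound 1 to compound 3 (0.61 log units; beyond the scatter). Compound 2 reads > 166000 nM, which is a limit of the assay. The change there is large: an at least 31-fold lower number from compound 2 to compound 3 (1.50 log units; beyond the scatter). The two compounds without the hydroxyl groups also differ from each other: an at least 7.9-fold higher number from compound 1 to compound 2 (0.89 log units; beyond the scatter).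

Compound 4 `OC[C@H]1O[C@@H](n2cnc3c(NCc4ccccc4OC(F)F)ncnc32)[C@H](O)[C@@H]1O` is still to be measured. Its change is 2-(difluoromethoxy)phenyl in place of 2,3-dihydroxyphenyl on a saturated chain carbon bound to a nitrogen on an aromatic ring, with 2-(difluoromethoxy)phenyl in place of 2,3-dihydroxyphenyl on a saturated chain carbon bound to a nitrogen on an aromatic ring. Like compound 1 and compound 2, it lacks the 2,3-dihydroxyphenyl group, so the two steps into compound 3 are the closest guide, read in reverse. A higher number is therefore expected in this assay, of modest to large size, and the expected step is a 7.7-fold higher number from compound 3 to compound 4 (0.89 log units; beyond the scatter). The estimate for compound 4 is 40000 nM, with an expected range from 12000 nM to 150000 nM.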

Compound 4, half-maximal inhibitory concentration: > 166000 nM
Compound 4: no number, only a limit; the forecaster's own chance of this, stated with the estimate: 20%; at least 4.1-fold (0.61 log units) between middle value and limit.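

In this assay, 2-(difluoromethoxy)phenyl in place of 2,3-dihydroxyphenyl on a saturated chain carbon bound to a nitrogen on an aromatic ring gives an at least 31-fold higher number from compound 3 to compound 4 (1.50 log units; beyond the scatter) and so shows that the loss seen with 2,3-dimethoxyphenyl is not confined to that one group. The same change also separates the new compound from the 4-fluorophenyl compound, with an at least 7.9-fold higher number from compound 1 to compound 4 (0.89 log units; beyond the scatter) on record, so 2-(difluoromethoxy)phenyl ranks below the halogenated group as well as below the 2,3-dihydroxyphenyl group at this position. Compound 2 and compound 4 cannot be ordered against each other, and their step cannot be read, because both stand at the same limit: the limit of > 166000 nM in this assay, at which 2 of the 4 values shown sit.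

The compounds shown do not tell how far compound 4 lies past that limit, since it has no exact number. They also leave open whether a single hydroxyl group on the phenyl ring, as in 2-hydroxyphenyl or 3-hydroxyphenyl, or an amine in its place, would keep the lower number of compound 3 or whether both hydroxyl groups of 2,3-dihydroxyphenyl are needed.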